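The compounds below may be only part of what the source reports. "The series", "measured", "known", "first", "only" and "open" are said of these compounds alone.

Compound 1 `Cc1ccnc(/C(N)=N/NC(=S)N2CCCC2)c1` gives 57.7% in a functional assay on MCF7 cells (Homo sapiens) for cytotoxicity, read by MTT assay, with a stated time of 72 h, tested at 3 uM (a higher number here means more inhibition of growth at the concentration tested, a lower number less inhibition of growth), the highest of the three numbers in hand. Compound 3 `N/C(=N\NC(=S)N1CCCCCC1)c1ccccn1` gives 56% in this assay, a number that lies within the usual scatter of compound 1, so the two cannot be told apart. Compound 2 `Cc1cccc(/C(N)=N/NC(=S)N2CCCCC2)n1` gives 27.1% in this assay, a number beyond the scatter below compound 1; compound 2 differs from compound 1 in more than one place, however, so no single change can be read from that pair.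

Compound 4 `Cc1ccnc(/C(N)=N/NC(=S)N2CCOCC2)c1` has not yet been measured. It differs from compound 1 in one place: morpholin-4-yl in place of pyrrolidin-1-yl on a thiocarbonyl carbon. Going by the values given here, no measured pair isolates a change of this kind, so nothing in hand fixes its size. The step from compound 1 to compound 4 is expected to be modest and downward, a number 9.7 percentage points lower from compound 1 to compound 4 (within the scatter), and may well fall within the scatter. Compound 4 is therefore expected to give about 48%, with a likely range from 30% to 64%.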

Compound 4, percent growth inhibition at one concentration: 5.07%
Estimate against measurement, compound 4: 42.9 percentage points above, and the stated range ends above it.
By their numbers in this assay, from the lowest: compound 4; then compound 2; then compounds 3 and 1 (each within the scatter of the next).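

On the thiocarbonyl carbon of the core of compound 1, the group proves decisive in this assay: morpholin-4-yl in place of pyrrolidin-1-yl gives a number 52.6 percentage points lower from compound 1 to compound 4 (beyond the scatter). Going by these compounds alone, this is the first pair to isolate a change at this place, and it shows that a single exchange of one non-aromatic ring for another can remove nearly all of the growth inhibition seen at the concentration tested. Nothing in hand bears on the reason for this loss.

The compounds shown do not separate the effect of the ring oxygen from that of going from a five-membered to a six-membered ring, a question that piperidin-1-yl on the core of compound 1 would address. From the compounds shown here alone, how 4-methylpiperazin-1-yl or an open-chain dimethylamino group would behave at this place also remains open.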